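Swapping a sulfur-linked ring for an oxygen-linked one

This account rests on a few compounds, and the source may have more. Where it says the series, first, only, none or still open, it means among the compounds named here.

Measured so far:
Compound 1, `Nc1cc(N)c2nc(-c3ccccc3)c(Oc3ccc(Cl)c(Cl)c3)nc2c1`: 31600 nM
Compound 2, `COc1ccc(Sc2nc3cc(N)cc(N)c3nc2-c2ccccc2)cc1`: < 100000 nM
Compound 3, `Nc1cc(N)c2nc(-c3ccccc3)c(Sc3ccc(Cl)c(Cl)c3)nc2c1`: < 100000 nM

In a functional assay on U-251 cells (Homo sapiens) for inhibition, read by sulforhodamine B assay, with a stated time of 48 h (a lower number here means a stronger inhibitor of growth, a higher number a weaker inhibitor of growth), compound 1 gives 31600 nM. For compound 3 this assay reports only a limit, < 100000 nM. Compound 2 likewise shows only a limit, < 100000 nM, so compound 3 cannot be placed against either neighbour: the steps a step that the limit leaves unreadable from compound 1 to compound 3 and a step that the two limits leave unreadable from compound 2 to compound 3 stay unreadable, as the limit of < 100000 nM in this assay, at which 2 of the 3 values shown sit, makes plain.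

Compound 4, `Nc1cc(N)c2nc(-c3ccccc3)c(Oc3ccc(F)cc3)nc2c1`, differs from compound 3 by 4-fluorophenoxy in place of (3,4-dichlorophenyl)sulfanyl on an aromatic carbon. Among the measured compounds shown here, the only compound sharing an oxygen link with a real value is compound 1. Because the step that the limit leaves unreadable from compound 1 to compound 3 cannot be read, no direction can be drawn; the step that the limit leaves unreadable from compound 3 to compound 4 is a guess anchored on compound 1. Compound 4 is expected near 40000 nM, within 10000 nM to 100000 nM.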

Compound 4, concentration for total growth inhibition: 79400 nM
Compound 4: middle estimate off by 2.0-fold (0.30 log units), on the low side; low and high end bracket the measured number.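

Among the compounds shown here, with the oxygen link kept, compound 1 and compound 4 give the first readable step at this position. In this assay, 4-fluorophenyl in place of 3,4-dichlorophenyl on the oxygen gives a 2.5-fold higher number from compound 1 to compound 4 (0.40 log units; beyond the scatter), so the number here changes with the ring on that oxygen, and compound 4 is the weaker inhibitor of growth. The steps involving compound 2 or compound 3 cannot be read: the limit of < 100000 nM in this assay, at which 2 of the 4 values shown sit.

This comparison rests on a single pair of oxygen-linked rings. From the compounds shown here alone, how an amine or a carboxylic acid on that ring would change the number stays open.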